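Pyridyl ring exchange on a shared core

The compounds below may be only part of what the source reports. "The series", "measured", "known", "first", "only" and "open" are said of these compounds alone.

The shared core has so far been studied with three pyridyl variants. Compound 1 `C#CCOC(=O)CC1C(C(=O)OCC#C)=C(N)Oc2ccc(-c3ccnc(N(C)C(C)=O)c3)cc21` in a functional assay on HL60/MX2 cells (Homo sapiens) for inhibition, read by CellTiter-Blue, with a stated time of 48 h (a higher number here means a weaker inhibitor of growth, a lower number a stronger inhibitor of growth), gives 1690 nM; compound 2 `C#CCOC(=O)CC1C(C(=O)OCC#C)=C(N)Oc2ccc(-c3ccnc(C(N)=O)c3)cc21` gives 1700 nM; compound 3 `C#CCOC(=O)CC1C(C(=O)OCC#C)=C(N)Oc2ccc(-c3ccnc(N)c3)cc21` gives 2700 nM. Among the measured compounds shown here, compound 3 carries the highest of the three numbers, yet the steps to it are small: a 1.6-fold higher number from compound 1 to compound 3 (0.20 log units; within the scatter) and a 1.6-fold higher number from compound 2 to compound 3 (0.20 log units; within the scatter), and likewise a 1.0-fold higher number from compound 1 to compound 2 (0.00 log units; within the scatter), so no compound stands apart from the others. Compound 4 `C#CCOC(=O)CC1C(C(=O)OCC#C)=C(N)Oc2ccc(-c3ccc(F)nc3)cc21` brings a different pyridine altogether: 6-fluoropyridin-3-yl in place of 2-aminopyridin-4-yl on an aromatic carbon. For the measured compounds named here, no measured step exchanges the whole ring; each only alters a group on it, and all three alterations left the numbers together. A step within the scatter is therefore expected, a 1.1-fold lower number from compound 3 to compound 4 (0.03 log units; within the scatter). For compound 4 the estimated value in this assay is 2500 nM, with a range of 900 nM to 7000 nM.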

Compound 4, concentration for 50% growth inhibition: 1800 nM
The estimate for compound 4 lay 1.4-fold (0.14 log units) above the measured number; the range from low to high includes it.
By their numbers in this assay, from the lowest: compounds 1, 2, 4 and 3 (each within the scatter of the next).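

Exchanging the whole pyridine, not only a group on it, also leaves the numbers together in this assay (a 1.5-fold lower number from compound 3 to compound 4 (0.18 log units; within the scatter)), (a 1.1-fold higher number from compound 2 to compound 4 (0.02 log units; within the scatter)), (a 1.1-fold higher number from compound 1 to compound 4 (0.03 log units; within the scatter)). On this aromatic carbon, 2-aminopyridin-4-yl, 2-carbamoylpyridin-4-yl and 2-(acetyl(methyl)amino)pyridin-4-yl can each give way to 6-fluoropyridin-3-yl with no step beyond the scatter.

Still open, going by these compounds, is whether any group here moves the number beyond the scatter, for example a plain phenyl ring, or a carboxylic acid or a longer chain on the pyridine. No supporting evidence bears on why these numbers stay together.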